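Benzoxazole acids: oral exposure and the carboxy-to-hydroxymethyl step

The source may report more compounds than this note shows. Statements on the series, on what has been measured and on what is new or still open speak of the compounds shown alone.

Measured compounds and values:
- compound 1 `C[C@H](c1ccc(-c2cc(Cl)ccc2-c2nc(=O)o[nH]2)cc1)N(CC1CC1)c1nc2c(C(=O)O)cccc2o1`: in an ADME assay on the whole organism (Macaca fascicularis) for pharmacokinetics, read by LC-MS, using cassette dosing, at a dose of 1 mg/kg by the oral route (on this read-out higher numbers stand for higher exposure at the dose given and lower numbers for lower exposure), compound 1 gives 1300 ng.h/mL
- compound 2 `CCCCN(c1nc2c(C(=O)O)cccc2o1)[C@H](C)c1ccc(-c2ccccc2-c2nnn[nH]2)cc1`: in this assay compound 2 gives 429 ng.h/mL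
- compound 3 `Cc1ccc(-c2nc(=O)o[nH]2)c(-c2ccc([C@@H](C)N(CC3CC3)c3nc4c(C(=O)O)cccc4o3)cc2)c1`: in this assay compound 3 gives 4830 ng.h/mL

Compound 2 stands lowest of the three numbers in this assay; compound 1 is nearest to it and compound 3 furthest, both gaps beyond the scatter. Going by the values given here, the one step between compounds that differ in a single place is a 3.7-fold higher number from compound 1 to compound 3 (0.57 log units; beyond the scatter), a modest rise.

Compound 4 `CCCCN(c1nc2c(CO)cccc2o1)[C@H](C)c1ccc(-c2ccccc2-c2nnn[nH]2)cc1` differs from compound 2 by hydroxymethyl in place of carboxy on an aromatic carbon. Among the compounds with values here, no measured step touches the carboxy group on the shared core; the step from compound 1 to compound 3 concerns a different position and a different pair of groups, so it gives no guide to this change. The expectation for compound 4 therefore rests on compound 2 alone, with a wide range: the step of a 1.2-fold lower number from compound 2 to compound 4 (0.09 log units; within the scatter) is estimated as small, and compound 4 is expected to give about 350 ng.h/mL in this assay, between 60 ng.h/mL and 2000 ng.h/mL.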

Compound 4, area under the concentration-time curve: 20 ng.h/mL
Estimate against measurement, compound 4: 18-fold (1.24 log units) above; the whole stated range lies above it.
By their numbers in this assay, from the lowest: compound 4; then compound 2; then compound 1; then compound 3.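

In this assay, the exchange of carboxy for hydroxymethyl on this aromatic carbon gives a 21-fold lower number from compound 2 to compound 4 (1.33 log units; beyond the scatter), so this position, untouched by the earlier step, can carry a large change in oral exposure. The change removes one oxygen and the double bond outside aromatic rings, while the counts of hydrogen-bond donors and acceptors stay the same, so those two counts do not follow the step in this pair. Nothing shown here bears on what lies behind the fall.

Open, from the compounds shown here alone, is where a primary amide or a methyl ester on the same aromatic carbon would stand relative to carboxy and hydroxymethyl. Also open, going by these compounds, is whether the same exchange on the core of compound 3 would give a step of similar size.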